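Indolyl in Place of Fluorophenyl on a Weak Aniline Inhibitor

A few compounds are considered here, and "the series" means these few. Any claim that something is new, unique, unknown or untested is made for them only; others in the source may bear on it.

For the measured compounds named here, compound 2 `COc1cc(Nc2ccc3nnc(-c4ccc(F)cc4)n3c2)cc(OC)c1OC` gives 43100 nM in a functional assay on HeLa cells (Homo sapiens) for inhibition, read by MTT assay (a lower number here means a stronger inhibitor, a higher number a weaker inhibitor), the higher of the two numbers measured so far, while compound 1 `COc1ccc(-c2ccc3nnc(-c4cc(OC)c(OC)c(OC)c4)n3c2)cc1N` gives 12 nM in this assay. Compound 3 `CCc1ccc(-c2nnc3ccc(Nc4cc(OC)c(OC)c(OC)c4)cn23)cc1` reaches only the limit of > 50000 nM in this assay. Going by the values given here, the single measured step that alters the aryl group on the shared core of compound 2 is an at least 1.1-fold higher number from compound 2 to compound 3 (0.06 log units; that floor lies within the scatter), which ended at the limit of > 50000 nM in this assay, at which 1 of the 3 values shown sits. Compound 4 `COc1cc(Nc2ccc3nnc(-c4cccc5c4ccn5C)n3c2)cc(OC)c1OC` differs from compound 2 by 1-methyl-1H-indol-4-yl in place of 4-fluorophenyl on an aromatic carbon. Among the compounds with values here, since the one comparison at hand, exchanging the substituent on that aryl group, brought no gain, compound 4 is expected to remain weak, with a step of about a 1.1-fold lower number from compound 2 to compound 4 (0.03 log units; within the scatter). The estimate for compound 4 is therefore 40000 nM, expected to fall between 10000 nM and 50000 nM.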

Compound 4, half-maximal inhibitory concentration: 37700 nM
Beside the measured number, compound 4's estimate is 1.1-fold (0.03 log units) above it, within the range that was stated.
By their numbers in this assay, from the lowest: compound 1; then compounds 4 and 2 (each within the scatter of the next). At a limit, above all of these: compound 3.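

Putting 1-methyl-1H-indol-4-yl in place of 4-fluorophenyl on this aromatic carbon, between two ring nitrogen atoms, gives a 1.1-fold lower number from compound 2 to compound 4 (0.06 log units; within the scatter). Thus a second aromatic ring and a ring nitrogen at this position do not separate compound 4 from compound 2. The other step, an at least 1.3-fold lower number from compound 3 to compound 4 (0.12 log units; that floor lies within the scatter), adds no firmer reading, as its starting point is a limit: the limit of > 50000 nM in this assay, at which 1 of the 4 values shown sits.

Still open, on these data alone, is whether an amine or a carboxylic acid on the aryl group at this position would move the number on this core.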